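A few compounds are considered here, and "the series" means these few. Any claim that something is new, unique, unknown or untested is made for them only; others in the source may bear on it.

In a functional assay on a cell-free system (plasma, Homo sapiens) for inhibition, with Plasma (Rattus norvegicus) as the target (on this read-out lower numbers stand for stronger inhibition and higher numbers for weaker inhibition), compound 1 `COc1c(C)cnc(COc2ccc3c(N4CCNCC4)cc(=O)oc3c2C)c1C` gives 5800 nM and compound 2 `CSCOc1ccc2c(N3CCNCC3)cc(=O)oc2c1C` gives 3400 nM on the shared core. Going by the values given here, these are the only two numbers so far, and compound 2 stands level with compound 1 within the scatter. Compound 3 `CSCCOc1ccc2c(N3CCNCC3)cc(=O)oc2c1C` is still unmeasured. Its difference from compound 2 ((methylsulfanyl)methyl in place of methylsulfanyl on a saturated chain carbon bound to an oxygen on an aromatic ring) turns (methylsulfanyl)methoxy into 2-(methylsulfanyl)ethoxy.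

Among the compounds with values here, one measured step bears on this place, a saturated chain carbon bound to an oxygen on an aromatic ring. Exchanging 4-methoxy-3,5-dimethylpyridin-2-yl for methylsulfanyl there gave a 1.7-fold lower number from compound 1 to compound 2 (0.23 log units; within the scatter) and so stayed within the scatter. Within the data shown here, no measured pair shows the present kind of change, so the support is thin. With that far bigger exchange giving only a 1.7-fold lower number from compound 1 to compound 2 (0.23 log units; within the scatter) as its step, no step beyond the scatter is expected in this assay for the present change. The expected step is a 1.0-fold higher number from compound 2 to compound 3 (0.01 log units; within the scatter) and it is an estimate only. For compound 3 the expected value is 3500 nM with an estimated range of 1300 nM to 9000 nM in this series.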

Compound 3, half-maximal inhibitory concentration: 1500 nM
Estimate against measurement, compound 3: 2.3-fold (0.37 log units) above; the measured number falls inside the stated range.
By their numbers in this assay, from the lowest: compound 3; then compounds 2 and 1 (each within the scatter of the next).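

In this assay, the saturated chain carbon bound to an oxygen on an aromatic ring now shows a step beyond the scatter: going from (methylsulfanyl)methoxy to 2-(methylsulfanyl)ethoxy gives a 2.3-fold lower number from compound 2 to compound 3 (0.36 log units; beyond the scatter), though modest in size. The far larger exchange of 4-methoxy-3,5-dimethylpyridin-2-yl for (methylsulfanyl)methyl gives a 3.9-fold lower number from compound 1 to compound 3 (0.59 log units; beyond the scatter), so compound 3 is the strongest inhibitor of the three, with its steps to both others beyond the scatter, and at this place the size of the exchanged group does not by itself set the size of the step. No measurement shown here offers an explanation for this gain.

A single step cannot say whether the number keeps falling with a longer chain carrying the methylsulfanyl group or whether 2-(methylsulfanyl)ethoxy is already the best length. It also leaves open whether the sulfur matters at all, a question that a 2-methoxyethoxy group or a plain alkyl chain of the same length would address in this assay.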